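The source may report more compounds than this note shows. Statements on the series, on what has been measured and on what is new or still open speak of the compounds shown alone.

Measured compounds:
Compound 1 `CC(=N)N1CCC(Oc2ccc3nc(C(C)C)n(Cc4ccc5ccc(C(=N)N)cc5c4)c3c2)CC1`: 5.7 nM in an assay on isolated protein for inhibition of serine protease 1 (Bos taurus); a lower number here means a stronger inhibitor, a higher number a weaker inhibitor
Compound 2 `CCCc1nc2ccc(OC3CCN(C(C)=N)CC3)cc2n1Cc1ccc2ccc(C(=N)N)cc2c1`: 6.8 nM in this assay
Compound 3 `CC(=N)N1CCC(Oc2ccc3nc(CCC(=O)O)n(Cc4ccc5ccc(C(=N)N)cc5c4)c3c2)CC1`: 18 nM in this assay

Compound 3 carries the highest of the three numbers. Its nearest neighbour is compound 2, and the step of a 2.6-fold higher number from compound 2 to compound 3 (0.42 log units; beyond the scatter) lies beyond the scatter; the step of a 3.2-fold higher number from compound 1 to compound 3 (0.50 log units; beyond the scatter) is somewhat larger still. The two steps between compound 1 and compound 2, a 1.2-fold higher number from compound 1 to compound 2 (0.08 log units; within the scatter), stay within the scatter.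

Compound 4 `CCCCc1nc2ccc(OC3CCN(C(C)=N)CC3)cc2n1Cc1ccc2ccc(C(=N)N)cc2c1` differs from compound 3 in one place: ethyl in place of carboxy on a saturated chain carbon, two bonds along the chain from an aromatic carbon. The step of a 2.6-fold higher number from compound 2 to compound 3 (0.42 log units; beyond the scatter) bears most directly on this change, since it records what the carboxy group did when it replaced a methyl at that same position; the step of a 3.2-fold higher number from compound 1 to compound 3 (0.50 log units; beyond the scatter) points the same way. Taking away the carboxy group and putting a plain ethyl in its place is therefore expected to undo that loss, so that the number for compound 4 in this assay falls back to the region of compound 1 and compound 2. The expected step is a 2.6-fold lower number from compound 3 to compound 4 (0.41 log units; beyond the scatter). Compound 4 is estimated at 7 nM, with a range from 3.5 nM to 14 nM.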

Compound 4, inhibition constant: 5.7 nM
The estimate for compound 4 lay 1.2-fold (0.09 log units) above the measured number; low and high end bracket the measured number.
By their numbers in this assay, from the lowest: compounds 1, 4 and 2 (each within the scatter of the next); then compound 3.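

In this assay the step of a 3.2-fold lower number from compound 3 to compound 4 (0.50 log units; beyond the scatter) shows that the higher number of compound 3 does not persist when butyl replaces the 2-carboxyethyl group, which ties that number to the carboxy end rather than to the presence of a chain at this position. The steps of a 1.2-fold lower number from compound 2 to compound 4 (0.08 log units; within the scatter) and no change at the digits printed from compound 1 to compound 4 (within the scatter) stay within the scatter, so isopropyl, propyl and butyl cannot be told apart here, and the position accepts a plain butyl chain with no measurable penalty. Nothing given here explains why the carboxy end raises the number.

Going by these compounds, whether a pentyl or longer chain would also leave the number in this region remains open. So does whether a methyl ester, an amide or an amine at the chain end would behave like the carboxylic acid or like butyl.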